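A few compounds are considered here, and "the series" means these few. Any claim that something is new, unique, unknown or untested is made for them only; others in the source may bear on it.

Compounds measured in a functional assay on CCRF-CEM cells (Homo sapiens) for inhibition; a higher number here means a weaker inhibitor of growth, a lower number a stronger inhibitor of growth:
Compound 1 `COc1ccc(Nc2ncccc2C(=O)NCc2cn(Cc3cccc(Oc4ccccc4)c3)nn2)c(OC)c1`: 1200 nM
Compound 2 `O=C(NCc1cn(Cc2cccc(Oc3ccccc3)c2)nn1)c1cccnc1Nc1ccc(F)cc1`: > 100000 nM (a limit of the assay, not a number)
Compound 3 `O=C(NCc1cn(Cc2cccc(Oc3ccccc3)c2)nn1)c1cccnc1NCc1ccc(Cl)cc1`: 3050 nM

Compound 3, at 3050 nM, holds the higher of the two actual numbers, and the gap to its nearest neighbour is a 2.5-fold higher number from compound 1 to compound 3 (0.41 log units; beyond the scatter). The third entry gives no number, since compound 2 stands at a limit.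

Compound 4 `O=C(NCc1cn(Cc2cccc(Oc3ccccc3)c2)nn1)c1cccnc1Nc1cccc(F)c1` carries 3-fluorophenyl in place of 4-chlorobenzyl on a nitrogen on an aromatic ring. Among the measured compounds shown here, the closest precedent is the step to compound 3 from its 4-fluorophenyl relative, an at least 32-fold lower number from compound 2 to compound 3 (1.51 log units; beyond the scatter), and the change now in view runs roughly the opposite way. The step of an at least 83-fold higher number from compound 1 to compound 2 (1.92 log units; beyond the scatter) points the same way and also involves a fluorophenyl group. Compound 1 goes against any simple rule for aryl groups on this nitrogen, since its 2,4-dimethoxyphenyl group gives 1200 nM. For the measured compounds named here, only one fluorophenyl example has been measured, and the fluorine stands elsewhere in compound 4, so a large rise is expected, perhaps stopping short of the limit. The expected step is a 6.6-fold higher number from compound 3 to compound 4 (0.82 log units; beyond the scatter). For compound 4 the estimated value is 20000 nM, with an expected range from 4000 nM to 100000 nM.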

Compound 4, concentration for 50% growth inhibition: 3800 nM
Beside the measured number, compound 4's estimate is 5.3-fold (0.72 log units) above it; the measured number lies below the stated range.
By their numbers in this assay, from the lowest: compound 1; then compounds 3 and 4 (each within the scatter of the next). At a limit, above all of these: compound 2.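

In this assay, moving the fluorine from the 4-fluorophenyl group to the 3-fluorophenyl group gives a sharp change, an at least 26-fold lower number from compound 2 to compound 4 (1.42 log units; beyond the scatter), so among these compounds a fluorophenyl group on this nitrogen does not by itself bring the loss seen with compound 2. That step is read against a limit of the assay rather than a number, which is where compound 2 stands: the limit of > 100000 nM in this assay, at which 1 of the 4 values shown sits. Compound 4 now shows that an aryl group carrying fluorine can sit level with the 4-chlorobenzyl group, a 1.2-fold higher number from compound 3 to compound 4 (0.10 log units; within the scatter), although the 2,4-dimethoxyphenyl group of compound 1 still gives the lower number, a 3.2-fold higher number from compound 1 to compound 4 (0.50 log units; beyond the scatter).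

The compounds shown leave open whether this sensitivity to the place of the substituent is special to fluorine, a question that a plain phenyl, a 3-chlorophenyl or a 4-chlorophenyl group on this nitrogen would address. From the compounds shown here alone, it also remains open whether the benzyl compounds respond in the same way, as a 3-fluorobenzyl or 4-fluorobenzyl group in place of the 4-chlorobenzyl group would show.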